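Sulfamoylphenyl in Place of Aminophenyl on a Triazole

The source may report more compounds than this note shows. Statements on the series, on what has been measured and on what is new or still open speak of the compounds shown alone.

Compound 1, `N#CC1=C(N)Oc2c(c3nc4ccccc4nc3c3ccccc23)C12C(=O)N(Cc1cnnn1-c1ccc(F)cc1)c1ccccc12`, gives a limit rather than a number in a functional assay on HepG2 cells (Homo sapiens) for antiproliferative activity, read by MTT assay, with a stated time of 48 h; on this read-out lower numbers stand for stronger inhibition and higher numbers for weaker inhibition: > 50000 nM.
Compound 2, `COc1ccc(-n2nncc2CN2C(=O)C3(C(C#N)=C(N)Oc4c3c3nc5ccccc5nc3c3ccccc43)c3ccccc32)cc1`, likewise gives a limit in this assay: > 50000 nM.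
Compound 3, `N#CC1=C(N)Oc2c(c3nc4ccccc4nc3c3ccccc23)C12C(=O)N(Cc1cnnn1-c1ccc(N)cc1)c1ccccc12`, also gives a limit in this assay: > 50000 nM.

Among the measured compounds shown here, compound 3 thus stands where every measured compound stands, at the limit of > 50000 nM in this assay, at which 3 of the 3 values shown sit, and no compound can be ranked against another. The steps from one to the next, a step that the two limits leave unreadable from compound 1 to compound 2, a step that the two limits leave unreadable from compound 1 to compound 3 and a step that the two limits leave unreadable from compound 2 to compound 3, are each unreadable in size because both ends are limits.

Compound 4, `N#CC1=C(N)Oc2c(c3nc4ccccc4nc3c3ccccc23)C12C(=O)N(Cc1cnnn1-c1cccc(S(N)(=O)=O)c1)c1ccccc12`, differs from compound 3 by 3-sulfamoylphenyl in place of 4-aminophenyl on an aromatic nitrogen. The measured steps that bear on this change are the three exchanges on the same aromatic carbon of the phenyl ring, and none of them shows a readable size, so they give no direction for the new substituent. Compound 4 is therefore expected to sit at the limit as well, with an estimated 50000 nM, ranging from 20000 nM to 50000 nM. The expected step of a number no higher from compound 3 to compound 4 (the limit leaves the size open) is estimated to be none beyond the scatter.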

Compound 4, half-maximal inhibitory concentration: 21500 nM
The estimate for compound 4 lay 2.3-fold (0.37 log units) above the measured number, within the range that was stated.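

With 3-sulfamoylphenyl on the aromatic nitrogen of the five-membered ring, this assay gives the first readable movement at this position: an at least 2.3-fold lower number from compound 3 to compound 4 (0.36 log units; beyond the scatter). The same exchange gives an at least 2.3-fold lower number from compound 2 to compound 4 (0.36 log units; beyond the scatter) when it replaces 4-methoxyphenyl and an at least 2.3-fold lower number from compound 1 to compound 4 (0.36 log units; beyond the scatter) when it replaces 4-fluorophenyl, whereas the steps among compound 1, compound 2 and compound 3 cannot be read. Each of these new steps is a lower bound, and compound 4 alone gives a number rather than a limit: the limit of > 50000 nM in this assay, at which 3 of the 4 values shown sit.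

The compounds shown leave open whether the sulfamoyl group itself or its place on the phenyl ring accounts for the step, a question that a 4-sulfamoylphenyl group or a 3-aminophenyl group at the same nitrogen would separate. They also leave open how the number would respond to a carboxylic acid or a methylsulfonyl group on that ring, and how far compound 4 truly lies from the other three compounds.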